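The source may report more compounds than this note shows. Statements on the series, on what has been measured and on what is new or still open speak of the compounds shown alone.

Measured compounds:
compound 1, `COc1cc(Oc2cccc(Nc3ccccc3)c2)cc(OC)c1CNCc1ccccc1`, gives 5220 nM
compound 2, `COc1cc(Oc2cccc(Nc3ccccc3)c2)cc(OC)c1CNCc1ccc(F)cc1`, gives 2650 nM
compound 3, `COc1cc(Oc2cccc(Nc3ccccc3)c2)cc(OC)c1CN[C@H](C)c1ccccc1`, gives 8570 nM

All three numbers come from a functional assay on DLD-1 cells (Homo sapiens) for inhibition, read by MTT assay, with a stated time of 72 h; on this read-out lower numbers stand for stronger inhibition and higher numbers for weaker inhibition. Compound 3 gives the highest number of the three; one of the two steps that end at it is a 1.6-fold higher number from compound 1 to compound 3 (0.22 log units; within the scatter), which lies within the scatter, while the other is a 3.2-fold higher number from compound 2 to compound 3 (0.51 log units; beyond the scatter), which lies beyond it.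

Compound 4, `CCN1CCN(Cc2c(OC)cc(Oc3cccc(Nc4ccccc4)c3)cc2OC)CC1`, is the unmeasured next step from compound 3. The change is 4-ethylpiperazin-1-yl in place of (1-phenylethyl)amino on a saturated chain carbon bound to an aromatic carbon.

The measured steps all alter the group on the amine nitrogen and are small: a 2.0-fold lower number from compound 1 to compound 2 (0.29 log units; within the scatter), a 1.6-fold higher number from compound 1 to compound 3 (0.22 log units; within the scatter) and a 3.2-fold higher number from compound 2 to compound 3 (0.51 log units; beyond the scatter). For the measured compounds named here, none of them exchanges the amine for a ring such as 4-ethylpiperazin-1-yl, so no step bears directly on this change. The data give no ground to expect a large movement in either direction.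

Compound 4 is therefore expected to give about 6000 nM in this assay, with a range from 2000 nM to 20000 nM. This estimate means a step of a 1.4-fold lower number from compound 3 to compound 4 (0.15 log units; within the scatter), which is expected to fall within the scatter.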

Compound 4, half-maximal inhibitory concentration: > 20000 nM
Compound 4: a limit, no number; the forecaster's own chance of this, stated with the estimate: 10%; middle value at least 3.3-fold (0.52 log units) from the limit.
By their numbers in this assay, from the lowest: compounds 2, 1 and 3 (each within the scatter of the next, the first and the last beyond it). At a limit, above all of these: compound 4.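

In this assay, compound 4 gives no number but a limit: the limit of > 20000 nM in this assay, at which 1 of the 4 values shown sits.

With 4-ethylpiperazin-1-yl on the saturated chain carbon bound to an aromatic carbon, all three steps lie beyond the scatter: an at least 2.3-fold higher number from compound 3 to compound 4 (0.36 log units; beyond the scatter), an at least 7.5-fold higher number from compound 2 to compound 4 (0.87 log units; beyond the scatter) and an at least 3.8-fold higher number from compound 1 to compound 4 (0.58 log units; beyond the scatter). For the compounds shown here, the earlier compounds varied only the group on the amine nitrogen and all gave a number, so this is the first sign that replacing the whole amino group at this place can take the read-out out of measurable range.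

The change removes the aromatic ring and the hydrogen-bond donor together, and the compounds shown do not separate the two. Going by these compounds, it stays open whether 4-benzylpiperazin-1-yl, which carries an aromatic ring, or open-chain ethylamino, which keeps the amine hydrogen, would give a number in this assay.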